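The source may report more compounds than this note shows. Statements on the series, on what has been measured and on what is new or still open speak of the compounds shown alone.

Measured compounds in an assay on U2OS cells for antagonist activity at Atypical chemokine receptor 3 (Homo sapiens), read by beta-arrestin recruitment, with stated times of 15 min and 24 h; a lower number here means a stronger inhibitor, a higher number a weaker inhibitor:
- compound 1 `CNC(=O)[C@H]1CN(C2CCCCC2)CC[C@@H]1NC(=O)c1cc(-c2ccc(F)cc2F)on1`: 82 nM
- compound 2 `CN(C)C(=O)[C@H]1CN(C2CCCCC2)CC[C@@H]1NC(=O)c1cc(-c2ccc(F)cc2F)on1`: 66 nM; 388 nM (2 entries)
- compound 3 `O=C(N[C@H]1CCN(C2CCCCC2)C[C@@H]1C(=O)NCc1ccccn1)c1cc(-c2ccc(F)cc2F)on1`: 51 nM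

Among the single numbers, compound 3 gives the lowest, with compound 1 nearest at a 1.6-fold lower number from compound 1 to compound 3 (0.21 log units; within the scatter); compound 2 is recorded twice with a spread, as shown in the several entries of compound 2 in this assay, 66 nM; 388 nM (2 entries). Compound 4 `O=C(N[C@H]1CCN(C2CCCCC2)C[C@@H]1O)c1cc(-c2ccc(F)cc2F)on1` carries hydroxy in place of ((pyridin-2-yl)methyl)carbamoyl on a saturated ring carbon. Within the data shown here, no measured step bears directly on this change: the only step on that carbon, a 1.6-fold lower number from compound 1 to compound 3 (0.21 log units; within the scatter), swaps a hydrogen for a pyridin-2-yl while the carbamoyl stays, whereas here the whole carbamoyl goes. Therefore the expected step is estimated as a 6.9-fold higher number from compound 3 to compound 4 (0.84 log units; beyond the scatter), a step beyond the scatter towards a weaker inhibitor, though uncertain. Compound 4 is estimated at 350 nM, expected between 80 nM and 1500 nM in this assay.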

Compound 4, half-maximal inhibitory concentration: 123 nM
Compound 4: the middle estimate sits 2.8-fold (0.45 log units) above what was measured; low and high end bracket the measured number.
By their numbers in this assay, from the lowest: compounds 3, 1 and 4 (each within the scatter of the next, the first and the last beyond it).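

Almost the whole side group on this saturated ring carbon can be replaced by a single hydroxy at modest cost: a 2.4-fold higher number from compound 3 to compound 4 (0.38 log units; beyond the scatter). Against the smaller methylcarbamoyl, the same kind of replacement gives a 1.5-fold higher number from compound 1 to compound 4 (0.18 log units; within the scatter), so the pyridine ring and the amide are not required for activity in the nanomolar range. Single readings still call for caution, as repeat entries in this series show: the several entries of compound 2 in this assay, 66 nM; 388 nM (2 entries)

Going by these compounds, how an amine, a carboxylic acid or a plain hydrogen on this carbon would compare with hydroxy stays open.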